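This account rests on a few compounds, and the source may have more. Where it says the series, first, only, none or still open, it means among the compounds named here.

Compound 3 `Clc1ccc(Cl)c(-c2nc(N3CCCCC3)c3nc[nH]c3n2)c1` and compound 1 `Cn1cnc2c(N3CCCCC3)nc(-c3cc(Cl)ccc3Cl)nc21` share one core and differ in a single spot: methyl in place of hydrogen on an aromatic nitrogen. In an assay on cells for displacement of a labelled ligand from adenosine receptor A1 (Homo sapiens), read by scintillation counting and radioligand binding, with a stated time of 60 min, tested at 10 uM (on this read-out higher numbers stand for more inhibition at the one concentration tested (going by the name of the read-out) and lower numbers for less inhibition), compound 3 gives 1.4%. In this assay compound 1 gives 13.2%. The change therefore made a number 11.8 percentage points higher from compound 3 to compound 1 (beyond the scatter). Compound 2 `Oc1cccc(-c2nc(N3CCCCC3)c3nc[nH]c3n2)c1` carries another aromatic group; the difference between the cores of compound 2 and compound 3 is not broken down here. In this assay compound 2 reaches only a limit of the assay, > 80%, namely (the limit of > 80% in this assay, at which 1 of the 3 values shown sits). Compound 4 `Cn1cnc2c(N3CCCCC3)nc(-c3cccc(O)c3)nc21` has not yet been measured and stands to compound 2 as compound 1 stands to compound 3: methyl in place of hydrogen on an aromatic nitrogen, the same change. From compound 2 to compound 4 a step of a number at least 5 percentage points lower from compound 2 to compound 4 (that floor lies within the scatter) is expected, resting on the modest rise seen in a number 11.8 percentage points higher from compound 3 to compound 1 (beyond the scatter) and on compound 2 already sitting at the limit. Compound 4 is estimated at 75%, between 45% and 95%.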

Compound 4, a percentage reported as inhibition, at one concentration (the size of the read-out at that concentration, not a potency): 78.5%
For compound 4 the middle estimate is 3.5 percentage points below the measured one; the range from low to high includes it.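

In this assay, methyl in place of hydrogen on an aromatic nitrogen gives a number at least 1.5 percentage points lower from compound 2 to compound 4 (that floor lies within the scatter), which is only a floor and not a full size, whereas 3-hydroxyphenyl in place of 2,5-dichlorophenyl gives a number 65.3 percentage points higher from compound 1 to compound 4 (beyond the scatter). The methyl change has now been tried on two cores, but whether it carries over from one to the other with the same size stays unsettled: the same change on two cores in this assay, a number 11.8 percentage points higher (beyond the scatter) from compound 3 to compound 1 and a number at least 1.5 percentage points lower (that floor lies within the scatter) from compound 2 to compound 4; the limit leaves it open whether they differ Compound 2 stands at a limit of the assay and not at an exact number: the limit of > 80% in this assay, at which 1 of the 4 values shown sits.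

The compounds shown leave open what a longer chain, such as ethyl, would give on that same nitrogen. They also leave open how an amine or a carboxylic acid in place of the hydroxyl on the phenyl ring would read in this assay.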